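The compounds below may be only part of what the source reports. "The series", "measured", "known", "first", "only" and "open" are said of these compounds alone.

The measured compounds:
Compound 1 `O=C(/C=C/c1ccc(N2CCCCC2)cc1)c1cccs1`, which in an ADME assay on PBMC cells (Homo sapiens) for cytotoxicity, with a stated time of 5 days (on this read-out lower numbers stand for stronger inhibition and higher numbers for weaker inhibition), gives > 100000 nM, a limit of the assay rather than a number.
Compound 2 `Cc1cc(C(=O)/C=C/c2ccc(N3CCCCC3)cc2)c(C)s1`, which in this assay gives 38200 nM.
Compound 3 `c1csc(C2=NNC(c3ccc(N4CCCCC4)cc3)C2)c1`, which in this assay gives 20800 nM.

Compound 3 has the lowest of the two numbers shown, but compound 2 sits within the usual scatter of it, so the two cannot be ranked. Compound 1 gives only a limit (the limit of > 100000 nM in this assay, at which 1 of the 3 values shown sits), so its place relative to the others is not known.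

Compound 4 `Ic1ccc(C2=NNC(c3ccc(N4CCCCC4)cc3)C2)s1` differs from compound 3 in one place: iodo in place of hydrogen on an aromatic carbon. Among the measured compounds shown here, only one measured step touches the same part of the molecule, the thiophen-2-yl group, though on a different core: an at least 2.6-fold lower number from compound 1 to compound 2 (0.41 log units; beyond the scatter). That step shows that altering this group can move the number in this assay by an at least modest amount toward stronger inhibition. An iodo group is a different change from two methyl groups, and the core of compound 3 is not the core of compound 1, so the carry-over is uncertain. The expected step for compound 4 is therefore a small one toward a lower number, a 1.6-fold lower number from compound 3 to compound 4 (0.20 log units; within the scatter), possibly within the scatter. Compound 4 is estimated at 13000 nM in this assay, with a range from 4000 nM to 45000 nM.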

Compound 4, half-maximal inhibitory concentration: > 100000 nM
Compound 4: a limit, no number; the forecaster's own chance of this, stated with the estimate: 5%; at least 7.6-fold (0.88 log units) between middle value and limit.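

On the shared core, one iodo group in place of hydrogen, on the aromatic carbon next to the ring sulfur, gives an at least 4.8-fold higher number from compound 3 to compound 4 (0.68 log units; beyond the scatter) in this assay and so points toward weaker inhibition, which turns thiophen-2-yl into 5-iodothiophen-2-yl. The earlier change to the thiophene group, made on a different core, gave an at least 2.6-fold lower number from compound 1 to compound 2 (0.41 log units; beyond the scatter) and went the other way, so these two steps show that changes on this group can move the number in either direction. Compound 4 gives a limit and not a number, so its step has a known lowest size but no known full size, and the top of the range now holds more than one compound: the limit of > 100000 nM in this assay, at which 2 of the 4 values shown sit.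

On these data alone, whether a smaller halogen such as chloro or bromo, or an amine, on the same carbon would also raise the number stays open. Also open, as far as these compounds go, is whether the iodo group would act the same way on the core of compound 1, where the starting compound already gives only a limit.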